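The source may hold more compounds than are shown below. What is called first, only, known or untested is meant among the compounds shown, and "the series" means these compounds.

Working notes on the series. Compound 1 `CN1CCN(C(=S)SCc2coc3ccccc3c2=O)CC1` carries 4-methylpiperazin-1-yl on the thiocarbonyl carbon and compound 2 `O=c1c(CSC(=S)N2CCOCC2)coc2ccccc12` carries morpholin-4-yl there; in a functional assay on MCF7 cells (Homo sapiens) for antiproliferative activity, read by MTT assay, with a stated time of 72 h (on this read-out lower numbers stand for stronger inhibition and higher numbers for weaker inhibition), compound 1 gives 22900 nM and compound 2 gives 4000 nM. Going by the values given here, the single measured step, a 5.7-fold lower number from compound 1 to compound 2 (0.76 log units; beyond the scatter), thus concerns only the amine on the thiocarbonyl carbon. Compound 3 `COc1ccc2occ(CSC(=S)N3CCCCC3)c(=O)c2c1` bears a different cyclic amine on the thiocarbonyl carbon together with a methoxy on the core. In this assay compound 3 gives only a limit, > 40000 nM, sitting at the limit of > 40000 nM in this assay, at which 1 of the 3 values shown sits. Compound 4 `O=c1c(CSC(=S)N2CCCCC2)coc2ccccc12` is not yet measured and differs from compound 3 by hydrogen in place of methoxy on an aromatic carbon. Among the compounds with values here, no measured step touches a methoxy on the core, so the step from compound 3 to compound 4 has no direct precedent; the nearest reference is compound 2, which shares the unsubstituted core and gives 4000 nM in this assay. With compound 3 at a limit, the size of the step cannot be fixed from the numbers shown. Compound 4 is expected to give 15000 nM (range 4000 nM to 40000 nM) in this assay. The estimated step is an at least 2.6-fold lower number from compound 3 to compound 4 (0.42 log units; beyond the scatter).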

Compound 4, half-maximal inhibitory concentration: 1700 nM
Compound 4: the middle estimate sits 8.8-fold (0.95 log units) above what was measured; measured number below the stated range.
By their numbers in this assay, from the lowest: compound 4; then compound 2; then compound 1. At a limit, above all of these: compound 3.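

Going by these compounds alone, on the aromatic carbon of the core, hydrogen in place of methoxy gives an at least 23-fold lower number from compound 3 to compound 4 (1.37 log units; beyond the scatter) in this assay, the first reading of any change at this place, and it shows that with piperidin-1-yl on the thiocarbonyl carbon the methoxy compound lies far on the weaker side of the unsubstituted one. On the unsubstituted core, piperidin-1-yl in place of morpholin-4-yl gives a 2.4-fold lower number from compound 2 to compound 4 (0.37 log units; beyond the scatter) and piperidin-1-yl in place of 4-methylpiperazin-1-yl gives a 13-fold lower number from compound 1 to compound 4 (1.13 log units; beyond the scatter), which places the three amines in the order piperidin-1-yl, morpholin-4-yl, 4-methylpiperazin-1-yl, from the lowest number up. The step at the aromatic carbon has only a lower bound, as compound 3 stands at a limit: the limit of > 40000 nM in this assay, at which 1 of the 4 values shown sits.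

On these data alone, whether methoxy carries the same penalty alongside morpholin-4-yl or 4-methylpiperazin-1-yl remains open. So does the outcome for a smaller substituent such as chlorine or methyl at that aromatic carbon, or for an open-chain amine such as diethylamino on the thiocarbonyl carbon.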